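Compound 1 and its chloro analogue: working notes

The source may report more compounds than this note shows. Statements on the series, on what has been measured and on what is new or still open speak of the compounds shown alone.

For the measured compounds named here, in a functional assay for inhibition, with Homo sapiens as the target (on this read-out lower numbers stand for an effect already at smaller amounts and higher numbers for an effect only at larger amounts of compound), compound 1 `CCC(=O)Nc1ccc(C2=NNC(=O)CC2)cc1` gives 0.64 ug/mL, the only actual number in this small series. Compound 2 `CN1N=C(c2ccc(N)cc2)CCC1=O` reports only a limit, > 46.4 ug/mL. Compound 3 `Nc1cccc(C2=NNC(=O)CC2)c1` likewise reports only a limit, > 46.4 ug/mL. The remaining picture is therefore (the limit of > 46.4 ug/mL in this assay, at which 2 of the 3 values shown sit). Going by the values given here, no measured pair yields a step, so nothing directly gauges a change on the propanoyl chain of compound 1.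

The next compound is compound 4 `O=C1CCC(c2ccc(NC(=O)CCCl)cc2)=NN1`, which keeps the core of compound 1 and changes only that chain, from propanoyl to (2-chloroethyl)carbonyl. The change is chloro in place of hydrogen on a saturated chain carbon, two bonds along the chain from a carbonyl carbon.

Among the compounds with values here, with no comparable step available, the expectation in this assay rests on compound 1 at 0.64 ug/mL alone. Expected is a 1.3-fold higher number from compound 1 to compound 4 (0.10 log units; within the scatter), which would lie within the usual scatter, with only a slight lean toward a higher number. For compound 4 the estimated value is 0.8 ug/mL, with an expected range from 0.2 ug/mL to 4 ug/mL.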

Compound 4, half-maximal effective concentration: 0.98 ug/mL
Compound 4: middle estimate off by 1.2-fold (0.09 log units), on the low side; low and high end bracket the measured number.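

In this assay, for the compounds shown here, the first direct reading on the chain gives a 1.5-fold higher number from compound 1 to compound 4 (0.19 log units; within the scatter), for chloro in place of hydrogen on a saturated chain carbon, two bonds along the chain from a carbonyl carbon. On this read-out the two compounds therefore count as alike, and this position accepts one chlorine with no difference that can be told from the scatter of repeated measurements. Compound 4 is the second compound in the series with an actual number, while compounds 2 and 3 remain limits rather than numbers and give no step to it: the limit of > 46.4 ug/mL in this assay, at which 2 of the 4 values shown sit.

Going by these compounds alone, one chloro group at one position is the only change seen on this chain, so it stays open whether a hydroxyl group, an amine, a carboxylic acid or a longer chain at the same place would leave the read-out equally undisturbed. Going by these compounds, the part played by the propanoyl amide itself also stays open; compounds 2 and 3 each differ from compound 1 in more than one place, and neither can be read as a single change.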